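From 4-methoxyphenyl to phenyl in compound 1

This account rests on a few compounds, and the source may have more. Where it says the series, first, only, none or still open, it means among the compounds named here.

In a functional assay on cells (Panel NCI-60 (60 carcinoma cell lines), Homo sapiens) for inhibition, read by colorimetric assay, with a stated time of 3 days (a lower number here means a stronger inhibitor of growth, a higher number a weaker inhibitor of growth), compound 1 (`COc1ccc(-c2cnc(NC(=O)CCCCCCNC(=O)C(O)(O)C(F)(F)F)s2)cc1`) gives 8510 nM as its reading. Within the data shown here, compound 3 (`COc1ccc2sc(NC(=O)CCCCCCNC(=O)C(O)(O)C(F)(F)F)nc2c1`) comes in at 12300 nM and the two numbers lie within the scatter of each other, so compound 1 holds no ranked place and simply shares the only measured level with compound 3. Compound 2 (`COc1ccc(NC(=O)CCCCCCNC(=O)C(O)(O)C(F)(F)F)cc1`) has no number, with its entry ("not determined" (no result reported)) standing in place of one.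

Compound 4 (`O=C(CCCCCCNC(=O)C(O)(O)C(F)(F)F)Nc1ncc(-c2ccccc2)s1`) takes compound 1 from 4-methoxyphenyl to phenyl: hydrogen in place of methoxy on an aromatic carbon, para to a large group (hydrogen in place of methoxy on an aromatic carbon). Among the measured compounds shown here, no pair of measured compounds differs in one place only, so this step has no direct precedent in this assay and its direction cannot be read from the series. For the measured compounds named here, the only guide is that compound 3 (12300 nM) and compound 1 (8510 nM) stay within the scatter of each other. No change beyond the scatter is therefore expected, and the range is kept wide. The estimated 1.2-fold higher number from compound 1 to compound 4 (0.07 log units; within the scatter) is expected to stay within the scatter. For compound 4 the expected value is 10000 nM with an estimated range from 5000 nM to 20000 nM as the working figure.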

Compound 4, concentration for total growth inhibition: 17000 nM
Beside the measured number, compound 4's estimate is 1.7-fold (0.23 log units) below it; the measured number falls inside the stated range.
By their numbers in this assay, from the lowest: compounds 1, 3 and 4 (each within the scatter of the next).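

In this assay, the series now has its first comparison of compounds that differ in one place only: a 2.0-fold higher number from compound 1 to compound 4 (0.30 log units; within the scatter). Replacing methoxy with hydrogen on this aromatic carbon, para to a large group, therefore gives no difference that can be separated from the scatter, and this single pair offers no sign that the methoxy group matters to the reading at this position. No measurement is available here to account for this result.

The compounds shown leave open whether fluorine, an amine or a carboxylic acid at the same position would give a reading beyond the scatter from compound 1. They also leave open whether a shorter or longer chain between the two amide groups would do so, as all the compounds shown carry the same chain.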